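A few compounds are considered here, and "the series" means these few. Any claim that something is new, unique, unknown or untested is made for them only; others in the source may bear on it.

Working notes on the series.

The series shares one core, seen in compound 1 `C#CCN(c1nc2ccc(F)cc2s1)c1nc2ccc(OC)cc2s1`. In a functional assay on MCF7 cells (Homo sapiens) for antiproliferative activity, read by MTT assay (a lower number here means a stronger inhibitor, a higher number a weaker inhibitor), compound 1 gives 27800 nM. Compound 2 `COc1ccc2nc(N(Cc3cc(-c4ccc(OC(F)(F)F)cc4)no3)c3nc4ccc(F)cc4s3)sc2c1` carries a 4-(trifluoromethoxy)phenyl on the isoxazole arm; in this assay compound 2 gives 17400 nM, the lowest of the three numbers, but the gaps to compound 1 and to compound 3 are both within the usual scatter, so the three compounds cannot be told apart on these data. Compound 3 `COc1ccc(-c2cc(CN(c3nc4ccc(F)cc4s3)c3nc4ccc(OC)cc4s3)on2)cc1`, with the methyl variant of that ether, gives 32400 nM; the step of a 1.9-fold higher number from compound 2 to compound 3 (0.27 log units; within the scatter) is within the scatter.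

Compound 4 `COc1ccc2nc(N(Cc3cc(-c4ccc(Br)cc4)no3)c3nc4ccc(F)cc4s3)sc2c1` differs from compound 2 as follows: bromo in place of trifluoromethoxy on an aromatic carbon. Going by the values given here, the only measured step that bears on this position is a 1.9-fold higher number from compound 2 to compound 3 (0.27 log units; within the scatter), which did not move the number beyond the scatter; that step exchanges one substituent on the same oxygen, whereas here the whole trifluoromethoxy leaves and bromo enters, so the comparison is loose. Among the compounds with values here, no other measured pair touches this ring. The expectation for compound 4 in this assay is therefore a step of a 1.1-fold higher number from compound 2 to compound 4 (0.06 log units; within the scatter) of no clear size beyond the scatter. Compound 4 is estimated at 20000 nM, with a range from 8000 nM to 50000 nM.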

Compound 4, half-maximal inhibitory concentration: 41200 nM
Compound 4: middle estimate off by 2.1-fold (0.31 log units), on the low side, within the range that was stated.
By their numbers in this assay, from the lowest: compounds 2, 1, 3 and 4 (each within the scatter of the next, the first and the last beyond it).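

Going by these compounds alone, at this position, on an aromatic carbon of a six-membered aromatic ring of carbon only, para to a large group, the change from 4-(trifluoromethoxy)phenyl to 4-bromophenyl gives in this assay a modest step, a 2.4-fold higher number from compound 2 to compound 4 (0.37 log units; beyond the scatter), the first measured step here to pass the scatter. The position is therefore not wholly indifferent to its substituent, although the bromo and methoxy compounds cannot be told apart: a 1.3-fold higher number from compound 3 to compound 4 (0.10 log units; within the scatter) is the step between them. Nothing measured here accounts for the step from trifluoromethoxy to bromo.

The compounds shown leave open whether the effect of this position extends beyond this narrow set of substituents. On these data alone, how an amine, a carboxylic acid or a longer alkyl chain in this place would read in this assay also remains open.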